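Halogenated aniline in place of dimethoxyaniline: an expected step

The compounds below may be only part of what the source reports. "The series", "measured", "known", "first", "only" and "open" are said of these compounds alone.

Compound 3 `COc1ccc(Nc2ncnc3cc(OC)c(OCCCCC(=O)Nc4ccc(S(N)(=O)=O)cc4)cc23)cc1OC` stands lowest of the two numbers in a functional assay on NCI-H1975 cells (Homo sapiens) for antiproliferative activity, read by MTT assay, with a stated time of 72 h (a higher number here means a weaker inhibitor, a lower number a stronger inhibitor), at 9230 nM. Compound 1 `C#Cc1cccc(Nc2ncnc3cc(OC)c(OCCCCC(=O)Nc4ccc(S(N)(=O)=O)cc4)cc23)c1` gives 18800 nM, so that a 2.0-fold lower number from compound 1 to compound 3 (0.31 log units; beyond the scatter). Compound 2 `COc1cc2ncnc(Nc3ccc(F)cc3)c2cc1OCCCCC(=O)Nc1ccc(S(N)(=O)=O)cc1` reaches only the limit of the assay, > 40000 nM. From those two, an at least 2.1-fold higher number from compound 1 to compound 2 (0.32 log units; beyond the scatter) and an at least 4.3-fold lower number from compound 2 to compound 3 (0.63 log units; beyond the scatter).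

Compound 4 `COc1cc2ncnc(Nc3cccc(Cl)c3F)c2cc1OCCCCC(=O)Nc1ccc(S(N)(=O)=O)cc1` differs from compound 3 by 3-chloro-2-fluorophenyl in place of 3,4-dimethoxyphenyl on a nitrogen on an aromatic ring. Every measured step here exchanges the same phenyl group, and the one halogenated aniline, compound 2, sat at the limit (the limit of > 40000 nM in this assay, at which 1 of the 3 values shown sits). The author therefore expects a higher number for compound 4, a 1.7-fold higher number from compound 3 to compound 4 (0.24 log units; within the scatter), and estimates compound 4 at 16000 nM, within 5000 nM to 40000 nM.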

Compound 4, half-maximal inhibitory concentration: 6930 nM
Beside the measured number, compound 4's estimate is 2.3-fold (0.36 log units) above it; measured number inside the range.
By their numbers in this assay, from the lowest: compounds 4 and 3 (each within the scatter of the next); then compound 1. At a limit, above all of these: compound 2.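

In this assay a halogenated phenyl on this nitrogen need not end at a limit, showing a 1.3-fold lower number from compound 3 to compound 4 (0.12 log units; within the scatter) and a 2.7-fold lower number from compound 1 to compound 4 (0.43 log units; beyond the scatter) as its steps. The two halogenated groups part clearly, with an at least 5.7-fold lower number from compound 2 to compound 4 (0.76 log units; beyond the scatter) on this change, so the presence of halogen alone does not set the number at this place. Compound 2 gives only a limit, not a number: the limit of > 40000 nM in this assay, at which 1 of the 4 values shown sits.

As far as these compounds go, whether an amine or a carboxylic acid on this phenyl group would keep the number stays open. So does whether a longer chain would move it.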